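Benzyloxycarbonyl in place of cyano: compound 3 to compound 4

The source may report more compounds than this note shows. Statements on the series, on what has been measured and on what is new or still open speak of the compounds shown alone.

In a functional assay on NALM-6 cells (Homo sapiens) for cytotoxicity, with a stated time of 72 h (a higher number here means that more compound is needed for the effect, a lower number that less compound is needed), compound 1 `C=C[C@@](C)(/C=C/c1ccc(O)c(CO)c1)CCC=C(C)C` gives 16400 nM, and compound 2 `C=C[C@@](C)(/C=C/c1ccc(O)c(/C=C/C(=O)c2ccccc2)c1)CCC=C(C)C` gives 4470 nM.

Compound 3 `C=C[C@@](C)(/C=C/c1ccc(O)c(/C=C/C#N)c1)CCC=C(C)C` reads > 43400 nM, which is a limit of the assay and not a number. Compound 3 thus stands at the limit of > 43400 nM in this assay, at which 1 of the 3 values shown sits.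

Compound 4 `C=C[C@@](C)(/C=C/c1ccc(O)c(/C=C/C(=O)OCc2ccccc2)c1)CCC=C(C)C` carries benzyloxycarbonyl in place of cyano on a double-bonded chain carbon bound to a double-bonded chain carbon.

For the measured compounds named here, two measured steps bear on this change. Cyano in place of benzoyl at that same place gives an at least 9.7-fold higher number from compound 2 to compound 3 (0.98 log units; beyond the scatter). The second step, which starts from a hydroxymethyl group, is an at least 2.6-fold higher number from compound 1 to compound 3 (0.42 log units; beyond the scatter). Going by these compounds, both steps lie beyond the scatter, and both end at the limit, so their full size remains open.

Going by the values given here, removing the cyano group is therefore expected to reverse much of the first step, although benzyloxycarbonyl is not the benzoyl group of compound 2, and no benzyloxycarbonyl compound has been measured yet. The expected change is an at least 5.4-fold lower number from compound 3 to compound 4 (0.73 log units; beyond the scatter), towards a lower number in this assay and beyond the scatter. For compound 4 the estimate is 8000 nM, with an expected range of 3000 nM to 25000 nM.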

Compound 4, half-maximal effective concentration: > 43400 nM
Compound 4: a limit, no number (the forecaster's own chance of this, stated with the estimate: 15%); middle value at least 5.4-fold (0.73 log units) from the limit.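

In this assay, benzyloxy in place of phenyl on the carbonyl carbon gives an at least 9.7-fold higher number from compound 2 to compound 4 (0.98 log units; beyond the scatter), so this position responds to a change one atom away from the carbonyl carbon and not only to the loss of the benzoyl group. Compound 2 and compound 4 both carry a carbonyl and a six-membered aromatic ring of carbon only on the chain, so these two features together do not secure the lower number of compound 2. The step between compound 3 and compound 4 cannot be read, since both ends are limits of the assay, and cyano and benzyloxycarbonyl now share the same limit at this place, while the benzoyl compound stays clear of it: the limit of > 43400 nM in this assay, at which 2 of the 4 values shown sit.

Going by these compounds, how far compound 3 and compound 4 lie beyond that limit, and whether they differ at all, remains open. Also open, on these data alone, is whether an N-benzyl carboxamide or a free carboxylic acid in place of benzyloxycarbonyl, or a methyl ketone in place of the benzoyl group of compound 2, would give a readable number in this assay.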